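Ethyl ester against the free acid in the series

The source may report more compounds than this note shows. Statements on the series, on what has been measured and on what is new or still open speak of the compounds shown alone.

Measured in a functional assay on A549 cells (Homo sapiens) for cytotoxicity, read by MTT assay, with a stated time of 72 h; a lower number here means a stronger inhibitor, a higher number a weaker inhibitor:
- compound 1 `Cc1oc2ncnc(Nc3cccc(Cl)c3)c2c1C(=O)NC(C)C`: > 1000000 nM (a limit)
- compound 2 `Cc1oc2ncnc(Nc3cccc(Cl)c3)c2c1C(=O)O`: 95500 nM

Among the compounds with values here, compound 2 holds the only true number so far, 95500 nM. The entry for compound 1, > 1000000 nM, is a limit of this assay and not a number; the evidence here is the limit of > 1000000 nM in this assay, at which 1 of the 2 values shown sits.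

Compound 3 `CCOC(=O)c1c(C)oc2ncnc(Nc3cccc(Cl)c3)c12` departs from compound 2 by ethyl in place of hydrogen on an oxygen next to a carbonyl group, or carboxy to ethoxycarbonyl.

Within the data shown here, the only measured step, an at least 10-fold lower number from compound 1 to compound 2 (1.01 log units; beyond the scatter), has hydroxy in place of isopropylamino on a carbonyl carbon, and compound 3 likewise carries no hydroxy on that carbonyl carbon, so a step to a higher number is expected in this assay, probably smaller than that one. The expected change is a 2.6-fold higher number from compound 2 to compound 3 (0.42 log units; beyond the scatter). Compound 3 is estimated at 250000 nM, within a range of 50000 nM to 1000000 nM.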

Compound 3, half-maximal inhibitory concentration: > 1000000 nM
Compound 3 was reported as a limit; the forecaster's own chance of this, stated with the estimate: 25%; middle value at least 4.0-fold (0.60 log units) away from the limit.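

In this assay, ethyl in place of hydrogen on this oxygen next to a carbonyl group gives an at least 10-fold higher number from compound 2 to compound 3 (1.01 log units; beyond the scatter), so the ester joins the amide in losing the measurable value of the free acid. Of the three compounds, only compound 2, with its carboxy group, gives a true number, while neither isopropylamino nor ethoxy on that carbonyl carbon does: the limit of > 1000000 nM in this assay, at which 2 of the 3 values shown sit. The step between compound 1 and compound 3 cannot be read, since both entries are limits and not numbers.

Open, going by these compounds, is whether a smaller group on that carbonyl carbon, such as methoxy or an unsubstituted amine, would return a true number in this assay. Also open, on these data alone, is whether a different acid, such as a tetrazole or a longer chain ending in a carboxylic acid, would match compound 2.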